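The source may hold more compounds than are shown below. What is called first, only, known or untested is meant among the compounds shown, and "the series" means these compounds.

Compound 2 `Cc1c(CCCC(=O)O)c2cccc(/C=C/c3ccc(OCCCCc4c(F)c(F)cc(F)c4F)cc3)c2n1CC(=O)O` stands lowest of the two numbers in a physicochemical assay for permeability, using PAMPA, with a stated time of 4 h, at pH 7.4, tested at 50 uM (a lower number here means that the compound crosses the layer more slowly, a higher number that the compound crosses the layer faster), giving 0.5 10^-6 cm/s. Compound 3 `Cc1c(Cl)cccc1CCCCOc1ccc(C#Cc2cccc3c(CCC(=O)O)c(C)n(CCCCC(=O)O)c23)cc1` gives 4.6 10^-6 cm/s in this assay, a gap beyond the scatter. Compound 1 `Cc1c(CCCC(=O)O)c2cccc(/C=C/c3ccc(OCCCCc4ccccc4)cc3)c2n1CC(=O)O` gives only a limit in this assay, < 0.05 10^-6 cm/s, a result that sits at the floor of what can be read (the limit of < 0.05 10^-6 cm/s in this assay, at which 1 of the 3 values shown sits). For the measured compounds named here, the one measured step, an at least 10-fold higher number from compound 1 to compound 2 (1.00 log units; beyond the scatter), shows that adding four fluorines to the chain-end ring raised the number beyond the scatter. Compound 4 `Cc1c(F)cccc1CCCCOc1ccc(/C=C/c2cccc3c(CCCC(=O)O)c(C)n(CC(=O)O)c23)cc1` differs from compound 2 by 3-fluoro-2-methylphenyl in place of 2,3,5,6-tetrafluorophenyl on a saturated chain carbon, four bonds along the chain from an oxygen on an aromatic ring, which removes three of those fluorines and adds a methyl. Because an at least 10-fold higher number from compound 1 to compound 2 (1.00 log units; beyond the scatter) linked fluorines to faster crossing, a modest drop is expected, a 1.7-fold lower number from compound 2 to compound 4 (0.22 log units; within the scatter). Compound 4 is therefore estimated at 0.3 10^-6 cm/s, between 0.1 10^-6 cm/s and 1 10^-6 cm/s.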

Compound 4, apparent permeability: 1.5 10^-6 cm/s
Beside the measured number, compound 4's estimate is 5.0-fold (0.70 log units) below it, and the stated range ends below it.
By their numbers in this assay, from the lowest: compound 2; then compound 4; then compound 3. At a limit, below all of these: compound 1.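

In this assay, 3-fluoro-2-methylphenyl in place of 2,3,5,6-tetrafluorophenyl at this chain end gives a 3.0-fold higher number from compound 2 to compound 4 (0.48 log units; beyond the scatter), so the number does not simply follow the count of fluorines. Set against plain phenyl, the same group gives an at least 30-fold higher number from compound 1 to compound 4 (1.47 log units; beyond the scatter). That step is only a lower bound, set by the limit on compound 1: the limit of < 0.05 10^-6 cm/s in this assay, at which 1 of the 4 values shown sits.

The compounds shown leave open whether the methyl or the single fluorine accounts for the rise, and how a 2-methylphenyl or a 3-fluorophenyl group would read at this position.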